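A few compounds are considered here, and "the series" means these few. Any claim that something is new, unique, unknown or untested is made for them only; others in the source may bear on it.

Measured so far in a functional assay on K562 cells (Homo sapiens) for cytotoxicity, read by ELISA, with a stated time of 4 days; on this read-out higher numbers stand for weaker inhibition and lower numbers for stronger inhibition:

- compound 1 `Clc1ccc(-c2cc(-c3ccoc3)cc(-c3ccc(Cl)s3)n2)cc1`: 19600 nM
- compound 2 `Clc1ccc(-c2cc(-c3ccoc3)cc(-c3cccnc3)n2)s1`: 18700 nM
- compound 3 `Cc1ccsc1-c1cc(-c2ccc(Cl)o2)cc(-c2ccc(Cl)cc2)n1`: 15600 nM

Compounds 1 and 2 share one core and differ only in one group: pyridin-3-yl in place of 4-chlorophenyl on an aromatic carbon. In this assay this change gave a 1.0-fold lower number from compound 1 to compound 2 (0.02 log units; within the scatter), so on that core the exchange left the read-out essentially where it was.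

For the measured compounds named here, compound 3 carries a different core; how its core differs from the core of compound 1 is not broken down here, so no counted step connects the two.

Compound 4 `Cc1ccsc1-c1cc(-c2ccc(Cl)o2)cc(-c2cccnc2)n1` is the partner of compound 3 in the same kind of change: pyridin-3-yl in place of 4-chlorophenyl on an aromatic carbon. The surroundings of the place are not identical to those in the first pair. In compound 1 the exchanged group sits meta to a 5-chlorothiophen-2-yl group and meta to a furan-3-yl group, whereas in compound 3 it sits meta to a 3-methylthiophen-2-yl group and meta to a 5-chlorofuran-2-yl group. The two cores are therefore related but not the same, and the step is treated as the same kind of change rather than the same change.

For compound 4 in this assay the expected step is a 1.0-fold lower number from compound 3 to compound 4 (0.02 log units; within the scatter), set beside the earlier 1.0-fold lower number from compound 1 to compound 2 (0.02 log units; within the scatter); this expectation rests on the near-flat result from compound 1 to compound 2 and on compound 3 giving 15600 nM as the starting point. The widened range reflects that the surroundings of the exchanged group differ between the two cores. The estimate for compound 4 is 15000 nM, expected to fall between 7000 nM and 32000 nM.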

Compound 4, half-maximal inhibitory concentration: 12300 nM
Compound 4: the middle estimate sits 1.2-fold (0.09 log units) above what was measured, within the range that was stated.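

In this assay putting pyridin-3-yl in place of 4-chlorophenyl gave a 1.3-fold lower number from compound 3 to compound 4 (0.10 log units; within the scatter) on the core of compound 3, and this step agrees with the earlier one on the core of compound 1: the same change on two cores in this assay, a 1.0-fold lower number (0.02 log units; within the scatter) from compound 1 to compound 2 and a 1.3-fold lower number (0.10 log units; within the scatter) from compound 3 to compound 4, 1.2-fold (0.08 log units) apart, within the scatter of two such steps.

On both cores, therefore, the exchange leaves the read-out within the scatter, and the near-flat result carries over from one core to the other in these two pairs. For the compounds shown here, this does not establish a rule for the whole series, does not explain why the read-out stays flat, and says nothing about any measure other than this cytotoxicity read-out, since only two cores are compared and neither pair shows a step beyond the scatter.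

The compounds shown carry only 4-chlorophenyl or pyridin-3-yl at this place, so it remains open whether an amine, a carboxylic acid or a longer chain there would move the number beyond the scatter. Also open, from the compounds shown here alone, is whether the exchange stays this flat on cores carrying groups other than the 5-chlorothiophen-2-yl, furan-3-yl, 3-methylthiophen-2-yl and 5-chlorofuran-2-yl groups seen here.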